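The source may report more compounds than this note shows. Statements on the series, on what has been measured and on what is new or still open speak of the compounds shown alone.

Measured so far in a functional assay on HCT-116 cells (Homo sapiens) for inhibition, read by sulforhodamine B assay, with a stated time of 48 h, tested at 0.1 uM; on this read-out higher numbers stand for a weaker effect at the one concentration tested and lower numbers for a stronger effect:
- compound 1 `O=C(Nc1cccc(-n2cc(-c3ccncc3)c(-c3cc(O)cc(Cl)c3)n2)c1)Nc1ccc(Cl)c(C(F)(F)F)c1` gives 103%
- compound 2 `COc1cc(Cl)cc(-c2nn(-c3cccc(NC(=O)Nc4cc(C(F)(F)F)cc(C(F)(F)F)c4)c3)cc2-c2ccncc2)c1` gives 97%

Compound 2 holds the lower of the two numbers in this assay, but its nearest neighbour, compound 1, sits within the scatter of it, so no order between the two can be read. Both numbers lie at the level of no measurable effect at the single concentration tested.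

Compound 3 `COc1cc(Cl)cc(-c2nn(-c3cccc(NC(=O)Nc4cccc(C(F)(F)F)c4)c3)cc2-c2ccncc2)c1` is the next compound in the series; it differs from compound 2 in one place: hydrogen in place of trifluoromethyl on an aromatic carbon. Among the compounds with values here, no pair of measured compounds shows a step of this kind, so nothing measured tells what one trifluoromethyl is worth here. With compound 2 already at the level of no effect in this assay, there is little room for a weaker signal and no measured ground for a stronger one; the step from this change is expected to stay within the scatter, in no set direction.

Compound 3 is therefore estimated at 98% in this assay, with a range of 85% to 110%. The expected step is a number 1 percentage points higher from compound 2 to compound 3 (within the scatter).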

Compound 3, a percentage reported as activity, at one concentration (the size of the read-out at that concentration, not a potency): 99%
For compound 3 the middle estimate is 1 percentage points below the measured one, within the range that was stated.
By their numbers in this assay, from the lowest: compounds 2, 3 and 1 (each within the scatter of the next).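

In this assay, within the data shown here, the series now has its one readable single-place step: hydrogen in place of trifluoromethyl on an aromatic carbon, meta to a trifluoromethyl group, comes to a number 2 percentage points higher from compound 2 to compound 3 (within the scatter). Compound 2 and compound 3 thus both stay at the level of no measurable effect at the one concentration tested, so this trifluoromethyl does not separate an inactive compound from an active one under these conditions, something the earlier pair, which differs in more than one place, could not show. No measured information bears on why the step is this small.

The compounds shown leave open whether any other group at this place, such as an amine or a carboxylic acid, would move the read-out away from the level of no effect. On these data alone, since compound 2 and compound 3 both sit at that level, a contribution of this trifluoromethyl may still exist but remain unseen, and its worth in a compound with a clear effect in this read-out stays unknown.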